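Dimethoxy on the benzyl ether of a naphthyl-trimethoxyphenyl methane

This account rests on a few compounds, and the source may have more. Where it says the series, first, only, none or still open, it means among the compounds named here.

Compound 1 `COc1ccc(C(OCc2ccccc2)c2cccc3ccccc23)c(OC)c1OC`: > 20000 nM
Compound 2 `COc1ccc(C(c2ccc(O)cc2)c2cccc3ccccc23)c(OC)c1OC`: 17400 nM

In a functional assay on MDA-MB-231 cells (Homo sapiens) for inhibition, read by sulforhodamine B assay, with a stated time of 48 h (on this read-out higher numbers stand for weaker inhibition and lower numbers for stronger inhibition), compound 1 gives only a limit, > 20000 nM. Compound 3 `COc1cc(COC(c2ccc(OC)c(OC)c2OC)c2cccc3ccccc23)cc(OC)c1` differs from compound 1 by 3,5-dimethoxyphenyl in place of phenyl on a saturated chain carbon bound to an oxygen on a saturated carbon. Among the compounds with values here, the one measured step, an at least 1.1-fold lower number from compound 1 to compound 2 (0.06 log units; that floor lies within the scatter), touches a different position and starts from the limit of > 20000 nM in this assay, at which 1 of the 2 values shown sits, so it sets no direction here. Compound 3 is therefore expected to sit near compound 1, with a step that the limit leaves unreadable from compound 1 to compound 3, most likely again as a limit. The estimate for compound 3 is 25000 nM, between 8000 nM and 80000 nM.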

Compound 3, half-maximal inhibitory concentration: > 20000 nM
Compound 3: no number, only a limit; the forecaster's own chance of this, stated with the estimate: 70%; the middle value does not contradict the limit.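

Compound 1 and compound 3 both give only limits, so no step between them can be read: the limit of > 20000 nM in this assay, at which 2 of the 3 values shown sit.

The compounds shown leave open whether 3,5-dimethoxybenzyl in place of benzyl changes inhibition at all.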